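A few compounds are considered here, and "the series" means these few. Any claim that something is new, unique, unknown or untested is made for them only; others in the source may bear on it.

The measured compounds:

Compound 1, `O=c1[nH]cnc2c1c(-c1ccco1)cn2[C@@H]1O[C@H](CO)[C@@H](O)[C@H]1O`. In a functional assay on CCRF-CEM cells (Homo sapiens), read by MTT assay, with a stated time of 72 h (a higher number here means a weaker inhibitor, a lower number a stronger inhibitor), compound 1 gives > 20000 nM, which is a limit of the assay rather than a number.

Compound 2, `Nc1nc2c(c(-c3ccco3)cn2[C@@H]2O[C@H](CO)[C@@H](O)[C@H]2O)c(=O)[nH]1`. In this assay compound 2 gives > 20000 nM, again a limit of the assay.

Compound 3, `O=c1[nH]cnc2c1c(-c1ccccc1)cn2[C@@H]1O[C@H](CO)[C@@H](O)[C@H]1O`. In this assay compound 3 gives > 100000 nM, also a limit of the assay.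

Compound 2 differs from compound 1 by one change, (amino in place of hydrogen on an aromatic carbon). The step it made is a step that the two limits leave unreadable from compound 1 to compound 2, since both ends of the step sit at limits. The two cores of compounds 1 and 3 differ as follows: phenyl in place of furan-2-yl on an aromatic carbon. The step here is likewise a step that the two limits leave unreadable from compound 1 to compound 3. So far, then, the three values show only that none of the compounds reaches a measurable concentration in this assay; one of them sits at the limit of > 100000 nM in this assay, at which 1 of the 3 values shown sits, and two at the limit of > 20000 nM in this assay, at which 2 of the 3 values shown sit.

Compound 4, `Nc1nc2c(c(-c3ccccc3)cn2[C@@H]2O[C@H](CO)[C@@H](O)[C@H]2O)c(=O)[nH]1`, has not yet been measured. It differs from compound 3 by amino in place of hydrogen on an aromatic carbon. Within the data shown here, this is the same change as the one from compound 1 to compound 2, and it sits in the same surroundings on the core of compound 3 as it did on the core of compound 1. Because a step that the two limits leave unreadable from compound 1 to compound 2 did not bring the value into the measurable range, and because compound 3 stands at the limit of > 100000 nM in this assay, at which 1 of the 3 values shown sits, the step from compound 3 to compound 4 is expected to be an at least 1.6-fold lower number from compound 3 to compound 4 (0.22 log units; that floor lies within the scatter), with compound 4 most likely left at a limit as well. The estimate for compound 4 in this assay is 60000 nM, with a range from 20000 nM to 200000 nM expected.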

Compound 4, half-maximal inhibitory concentration: > 100000 nM
Compound 4 ended at the assay's limit; the forecaster's own chance of this, stated with the estimate: 85%; at least 1.6-fold (0.22 log units) between middle value and limit.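

In this assay compound 4 gives > 100000 nM, which is a limit of the assay. The steps from compound 3 to compound 4 and from compound 2 to compound 4 cannot be read: both ends of each are limits. The compounds shown leave open what either change, amino in place of hydrogen or phenyl in place of furan-2-yl, does to the value in this assay, as none of the four gives a number.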